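A few compounds are considered here, and "the series" means these few. Any claim that something is new, unique, unknown or untested is made for them only; others in the source may bear on it.

Compound 1, `COc1ccc(-c2nnc(SCC(=O)c3ccccc3)n2-c2ccccc2)cc1OC`, is one of three compounds tested in a functional assay on the whole organism (strain albino) for inhibition, with Rattus norvegicus as the target, read by paw edema, with a stated time of 3 h, at a dose of 0.28 mmol/kg by the oral route; a lower number here means less inhibition, a higher number more inhibition at the dose given (going by the name of the read-out). In this assay compound 1 gives 59%, the lowest of the three numbers, although the other two lie within the scatter of it: compound 2, `COc1ccc(-c2nnc(SC/C(=N/O)c3ccccc3)n2-c2ccccc2)cc1OC`, gives 67% and compound 3, `CCn1c(SCC(=O)c2ccccc2)nnc1-c1ccc(OC)c(OC)c1`, gives 61%. The step of a number 8 percentage points higher from compound 1 to compound 2 (within the scatter) and the step of a number 2 percentage points higher from compound 1 to compound 3 (within the scatter) are both within the scatter. Compound 4, `COc1ccc(-c2nnc(SCC(=O)c3ccccc3)n2-c2ccccc2)cc1`, differs from compound 1 in a single place: hydrogen in place of methoxy on an aromatic carbon. Going by the values given here, no measured step removes a methoxy group, so neither bears directly on this change; both only show that a single change to compound 1 left this assay within the scatter. A step of similar size, with no clear direction, is therefore expected, a number 2 percentage points lower from compound 1 to compound 4 (within the scatter). Compound 4 is estimated at 57%, with a range from 42% to 70%.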

Compound 4, a percentage reported as inhibition, in the whole organism at one dose (the size of the read-out at that dose, not a potency): 58%
Estimate against measurement, compound 4: 1 percentage points below, and the stated range covers the measured number.
By their numbers in this assay, from the lowest: compounds 4, 1, 3 and 2 (each within the scatter of the next).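

The change from 3,4-dimethoxyphenyl to 4-methoxyphenyl gives a number 1 percentage points lower from compound 1 to compound 4 (within the scatter) in this assay. Going by these compounds alone, this is the first direct test of this position, and at this single dose the compound keeps its inhibition of paw edema without this methoxy group. No evidence is available that bears on this result. 

Going by these compounds, it remains open whether an amine, a hydroxyl or a longer chain such as ethoxy on this aromatic carbon would shift the number beyond the scatter. Removing the remaining methoxy group is also an untested change among the compounds shown.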